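Adding a chloro group to the lactam core of compound 3

The compounds below may be only part of what the source reports. "The series", "measured", "known", "first", "only" and "open" are said of these compounds alone.

Compound 1 `COc1cc(/C=C2\C(=O)Nc3ccc(Cl)cc32)ccc1OCCCN1CC(C)OC(C)C1` gives 6250 nM in a functional assay on A549 cells (Homo sapiens) for cytotoxicity, read by MTT assay, with a stated time of 48 h; a higher number here means a weaker inhibitor, a lower number a stronger inhibitor.
Compound 2 `COc1cc(/C=C2\C(=O)Nc3ccc(C)cc32)ccc1OCCCN1CC(C)OC(C)C1` gives > 20000 nM, which is a limit of this assay.
Compound 3 `COc1cc(/C=C2\C(=O)Nc3ccccc32)ccc1OCCCN1CCN(c2ccccn2)CC1` gives > 20000 nM, also a limit of this assay.

In this assay compound 3 thus sits at the limit (the limit of > 20000 nM in this assay, at which 2 of the 3 values shown sit), with no number of its own. Compound 4 `COc1cc(/C=C2\C(=O)Nc3ccc(Cl)cc32)ccc1OCCCN1CCN(c2ccccn2)CC1` differs from compound 3 by chloro in place of hydrogen on an aromatic carbon. Going by the values given here, no measured pair shows hydrogen replaced by chloro directly. The nearest comparison is an at least 3.2-fold higher number from compound 1 to compound 2 (0.50 log units; beyond the scatter), where chloro outperformed methyl. That suggests chloro is favourable at this position, so compound 4 is expected to give a lower number than the limit of compound 3, though possibly still near it. The estimate for compound 4 is 10000 nM (range 4000 nM to 25000 nM), a step of an at least 2.0-fold lower number from compound 3 to compound 4 (0.30 log units; that floor lies within the scatter) that is expected rather than established.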

Compound 4, half-maximal inhibitory concentration: > 20000 nM
Compound 4: no number, only a limit; the forecaster's own chance of this, stated with the estimate: 40%; middle value at least 2.0-fold (0.30 log units) from the limit.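

With the 4-(pyridin-2-yl)piperazin-1-yl group in place, chloro on this aromatic carbon does not bring compound 4 off the limit in this assay, so the step from compound 3 cannot be read. Keeping chloro and changing only the group on the chain gives an at least 3.2-fold higher number from compound 1 to compound 4 (0.50 log units; beyond the scatter), so chloro alone does not secure a measurable value. Little can yet be ranked: the limit of > 20000 nM in this assay, at which 3 of the 4 values shown sit.

Going by these compounds, whether chloro improves on hydrogen when the chain carries 2,6-dimethylmorpholin-4-yl stays open. So does whether bromo or fluoro at this carbon, or a plain morpholine on the chain, would give a readable number.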